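Swapping a furan amide for a tert-butylphenyl amide in a cytotoxicity series

The source may report more compounds than this note shows. Statements on the series, on what has been measured and on what is new or still open speak of the compounds shown alone.

The account follows two benzimidazole-type compounds that share a core and differ only in the group carried on the carbonyl. Compound 1 `CN(C)c1cc2[nH]c(C3CCCCC3)nc2cc1NC(=O)c1ccco1` carries a furan-2-yl group there. In an ADME assay on Vero cells (Chlorocebus sabaeus) for cytotoxicity, read by resazurin assay, with a stated time of 3 days (on this read-out higher numbers stand for weaker inhibition and lower numbers for stronger inhibition), compound 1 gives > 100 ug/mL, which is a limit of the assay rather than a number. Compound 2 `CCCN(CCC)c1cc2[nH]c(C3CCCCC3)nc2cc1NC(=O)OCc1ccccc1`, with a different amine and a benzyl carbamate, also sits at a limit. In this assay compound 2 gives > 100 ug/mL. Both values fall on (the limit of > 100 ug/mL in this assay, at which 2 of the 2 values shown sit), so compound 1 stands at the limit with nothing to rank it against.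

Compound 3 `CN(C)c1cc2[nH]c(C3CCCCC3)nc2cc1NC(=O)c1ccc(C(C)(C)C)cc1` is not yet measured. It differs from compound 1 by 4-(tert-butyl)phenyl in place of furan-2-yl on a carbonyl carbon. No measured step exists between the compounds shown, so the size of the step cannot be read from data. The step from compound 1 to compound 3 is expected to be a number no higher from compound 1 to compound 3 (the limit leaves the size open), that is, none beyond the scatter. Compound 3 is therefore expected to give about 100 ug/mL in this assay, within a range of 40 ug/mL to 200 ug/mL.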

Compound 3, half-maximal inhibitory concentration: > 100 ug/mL
Compound 3 gave a limit, no number (the forecaster's own chance of this, stated with the estimate: 65%); the middle value sits exactly at the limit.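

No step can be read between compound 1 and compound 3, as both values in this assay are limits and not numbers: the limit of > 100 ug/mL in this assay, at which 3 of the 3 values shown sit. The compounds shown leave open whether 4-(tert-butyl)phenyl in place of furan-2-yl changes cytotoxicity at all, since none yields a number to compare.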